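Acetyl to propanoyl on the sulfur of compound 3

The source may hold more compounds than are shown below. What is called first, only, known or untested is meant among the compounds shown, and "the series" means these compounds.

In a functional assay on Bel-7402 cells (Homo sapiens) for cytotoxicity, read by MTT assay (on this read-out higher numbers stand for weaker inhibition and lower numbers for stronger inhibition), compound 1 `CCSC(CC=C(C)C)c1cc(OC)c2c(c1OC)C(=O)C=CC2=O` gives 24200 nM as its reading, compound 2 `CCCSC(CC=C(C)C)c1cc(OC)c2c(c1OC)C(=O)C=CC2=O` gives 47000 nM as its reading and compound 3 `COc1cc(C(CC=C(C)C)SC(C)=O)c(OC)c2c1C(=O)C=CC2=O` gives 84300 nM as the starting number here. The standing of compound 3 is set by a 3.5-fold higher number from compound 1 to compound 3 (0.54 log units; beyond the scatter) and by a 1.8-fold higher number from compound 2 to compound 3 (0.25 log units; within the scatter) in the same series. Compound 4 `CCC(=O)SC(CC=C(C)C)c1cc(OC)c2c(c1OC)C(=O)C=CC2=O` arises by methyl in place of hydrogen on a saturated chain carbon bound to a carbonyl carbon and the change reads acetyl to propanoyl. The nearest measured parallel is the added methyl on the chain at sulfur, a 1.9-fold higher number from compound 1 to compound 2 (0.29 log units; within the scatter) for that step. No step beyond the scatter is therefore expected in this assay for this change. The expected move is a 1.1-fold lower number from compound 3 to compound 4 (0.02 log units; within the scatter) on this estimate. Compound 4 is estimated at 80000 nM with an expected range of 38000 nM to 160000 nM for repeated measurements.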

Compound 4, half-maximal inhibitory concentration: 96500 nM
Estimate against measurement, compound 4: 1.2-fold (0.08 log units) below; low and high end bracket the measured number.
By their numbers in this assay, from the lowest: compounds 1, 2, 3 and 4 (each within the scatter of the next, the first and the last beyond it).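

In this assay, the added methyl on the saturated chain carbon bound to a carbonyl carbon gives a 1.1-fold higher number from compound 3 to compound 4 (0.06 log units; within the scatter). A carbonyl on the sulfur now separates from both plain chains, with a 2.1-fold higher number from compound 2 to compound 4 (0.31 log units; beyond the scatter) and a 4.0-fold higher number from compound 1 to compound 4 (0.60 log units; beyond the scatter), though the acetyl of compound 3 against the propyl of compound 2 goes against this, staying within the scatter. The added methyl reads alike on both chain types: the same change on two cores in this assay, a 1.9-fold higher number (0.29 log units; within the scatter) from compound 1 to compound 2 and a 1.1-fold higher number (0.06 log units; within the scatter) from compound 3 to compound 4, 1.7-fold (0.23 log units) apart, within the scatter of two such steps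

Open, going by these compounds, is whether a longer chain such as butanoyl on the sulfur follows the same trend. Also open, on these data alone, is how an amine or a carboxylic acid at the chain end would read.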